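Ring Contraction on the Thiocarbonyl Nitrogen

A few compounds are considered here, and "the series" means these few. Any claim that something is new, unique, unknown or untested is made for them only; others in the source may bear on it.

For the measured compounds named here, compound 2 `N/C(=N\NC(=S)N1CCCCC1)c1ccccn1` holds the upper of the two numbers so far in a functional assay on A-431 cells (Homo sapiens) for cytotoxicity, read by MTT assay, with a stated time of 72 h (on this read-out lower numbers stand for stronger inhibition and higher numbers for weaker inhibition), where compound 2 gives 6900 nM; its nearest neighbour, compound 1 `N/C(=N\NC(=S)N1CCSCC1)c1ccccn1`, gives 6700 nM in this assay, and the step of a 1.0-fold higher number from compound 1 to compound 2 (0.01 log units; within the scatter) lies within the scatter. Compound 3 `N/C(=N\NC(=S)N1CCCC1)c1ccccn1` differs from compound 2 in one place: pyrrolidin-1-yl in place of piperidin-1-yl on a thiocarbonyl carbon. Going by the values given here, the single step measured on the same thiocarbonyl carbon was flat, so a further change of the ring there is expected to give no change at the digits printed from compound 2 to compound 3 (within the scatter), nothing beyond the scatter. Compound 3 is accordingly estimated at 6900 nM, within a range from 3500 nM to 14000 nM.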

Compound 3, half-maximal inhibitory concentration: 1700 nM
Estimate against measurement, compound 3: 4.1-fold (0.61 log units) above; the whole stated range lies above it.
By their numbers in this assay, from the lowest: compound 3; then compounds 1 and 2 (each within the scatter of the next).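

In this assay, the thiocarbonyl carbon proves sensitive to the ring it carries: pyrrolidin-1-yl gives a 4.1-fold lower number from compound 2 to compound 3 (0.61 log units; beyond the scatter) and a 3.9-fold lower number from compound 1 to compound 3 (0.60 log units; beyond the scatter) while thiomorpholin-4-yl and piperidin-1-yl had stayed within the scatter of each other. At this place, the number therefore moved with the five-membered ring, not with the exchange between the two six-membered rings. Nothing available bears on why this step occurs.

From the compounds shown here alone, whether azetidin-1-yl or an open-chain dimethylamino group would lower the number further remains open. So does whether a substituted pyrrolidin-1-yl would keep the step.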